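A Shorter Unsaturated Chain on the Amide of Compound 3

The compounds below may be only part of what the source reports. "The series", "measured", "known", "first", "only" and "open" are said of these compounds alone.

In a functional assay on MGC-803 cells (Homo sapiens) for inhibition, read by MTT assay, with a stated time of 48 h (a higher number here means a weaker inhibitor, a lower number a stronger inhibitor), compound 3 `C/C=C/C=C/C(=O)N(Cc1ccc(OC)c(O)c1)c1cc(OC)c(OC)c(OC)c1` gives 140 nM, the lowest of the two numbers reported so far. Compound 2 `C/C=C/C(=O)N(Cc1cc(OC)c(OC)c(OC)c1)c1ccc(OC)c(O)c1` gives 6150 nM in this assay, a gap from compound 3 that lies beyond the usual scatter. For compound 1 `COc1cc(NCc2ccccc2)cc(OC)c1OC`, this assay reports only a limit, > 80000 nM (the limit of > 80000 nM in this assay, at which 1 of the 3 values shown sits). Compound 4 `C/C=C/C(=O)N(Cc1ccc(OC)c(O)c1)c1cc(OC)c(OC)c(OC)c1` has not yet been measured; it differs from compound 3 by methyl in place of prop-1-en-1-yl on a double-bonded chain carbon bound to a double-bonded chain carbon. Among the measured compounds shown here, no measured pair shows this change directly, so its size is uncertain. Replacing the longer unsaturated chain with the shorter one is expected to weaken inhibition in this assay by a moderate step, a 5.7-fold higher number from compound 3 to compound 4 (0.76 log units; beyond the scatter). Compound 4 is therefore estimated at 800 nM, with a range of 200 nM to 4000 nM.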

Compound 4, half-maximal inhibitory concentration: 27 nM
Beside the measured number, compound 4's estimate is 30-fold (1.47 log units) above it, and the stated range ends above it.
By their numbers in this assay, from the lowest: compound 4; then compound 3; then compound 2. At a limit, above all of these: compound 1.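

In this assay, among the compounds shown here, the first pair to read this position directly shows that the longer chain is not needed here: cutting penta-1,3-dien-1-yl back to prop-1-en-1-yl on the carbonyl gives a 5.2-fold lower number from compound 3 to compound 4 (0.71 log units; beyond the scatter). This one pair makes the shorter unsaturated chain the stronger inhibitor on this core. The compounds shown offer no measurement that explains this step.

Going by these compounds, it remains open how a saturated propyl chain, a plain methyl on the carbonyl or a terminal amine on the chain would compare. On these data alone, whether the same shortening holds with other groups on the shared core also remains open.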